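The compounds below may be only part of what the source reports. "The series", "measured", "known", "first", "only" and "open" are said of these compounds alone.

Compound 1, with the structure `C=CC1=C(C(=O)NCc2ccccc2)C(c2ccc(OC)cc2)OC1`, anchors this small set: in a functional assay on SW480 cells (Homo sapiens) for cytotoxicity, read by MTT assay, with a stated time of 24 h (on this read-out lower numbers stand for stronger inhibition and higher numbers for weaker inhibition), compound 1 gives 39500 nM. Compound 2, `C=CC1=C(C(=O)NCc2ccc(Cl)cc2)C(c2ccc(OC)cc2)OC1`, differs from it by chloro in place of hydrogen on an aromatic carbon. In this assay compound 2 reaches only the limit of the measurement, > 100000 nM, so its standing is known as a bound rather than a number. The step of an at least 2.5-fold higher number from compound 1 to compound 2 (0.40 log units; beyond the scatter) is accordingly a lower bound on the loss, with compound 2 sitting at the limit of > 100000 nM in this assay, at which 1 of the 2 values shown sits. Compound 3, `C=CC1=C(C(=O)NCCCCC)C(c2ccc(OC)cc2)OC1`, has not yet been measured. Relative to compound 2 the change is butyl in place of 4-chlorophenyl on a saturated chain carbon bound to an amide-type nitrogen. No measured step touches this kind of exchange; the only step shown, an at least 2.5-fold higher number from compound 1 to compound 2 (0.40 log units; beyond the scatter), concerns a chloro on the ring that compound 3 no longer carries. The step of an at least 1.6-fold lower number from compound 2 to compound 3 (0.22 log units; that floor lies within the scatter) is expected to be modest and downward, though a limit remains a real possibility. Compound 3 is estimated at 60000 nM, within 20000 nM to 200000 nM.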

Compound 3, half-maximal inhibitory concentration: > 100000 nM
Compound 3 gave a limit, no number; the forecaster's own chance of this, stated with the estimate: 40%; middle value at least 1.6-fold (0.22 log units) from the limit.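

In this assay, butyl in place of phenyl on a saturated chain carbon bound to an amide-type nitrogen gives an at least 2.5-fold higher number from compound 1 to compound 3 (0.40 log units; beyond the scatter), so this place has now lost activity through two different changes: a chloro added to the ring, and the ring replaced by an open chain. The value of compound 3 is a limit of the assay, > 100000 nM. Compound 2 also stands at a limit, so the step between these two cannot be read, and compound 1 remains the only compound in the set with a number: the limit of > 100000 nM in this assay, at which 2 of the 3 values shown sit.

The compounds shown leave open how far compound 2 and compound 3 actually lie from each other, and whether either is truly inactive or only weaker than the assay can report. They also leave open whether an amine, a carboxylic acid or a chain longer than butyl at this place would give a value below that of compound 1, which stands at 39500 nM.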